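Replacing the oxazol-2-yl group of compound 1

This account rests on a few compounds, and the source may have more. Where it says the series, first, only, none or still open, it means among the compounds named here.

Compound 1 `COc1cc2nccc(Oc3ccc(NC(=O)c4ncc(-c5ccc(F)cc5)o4)cc3)c2cc1OC`: 21900 nM
Compound 2 `COc1cc2c(Oc3ccc(NC(=O)C4(c5nnc(-c6ccc(F)cc6)o5)CC4)cc3F)ccnc2cc1OCCCN1CCC(C)CC1`: 2180 nM

In a functional assay on PC-3 cells (Homo sapiens) for antiproliferative activity, read by MTT assay, with a stated time of 72 h (a higher number here means a weaker inhibitor, a lower number a stronger inhibitor), compound 1 stands highest of the two at 21900 nM, and its nearest neighbour, compound 2, gives 2180 nM. The gap between these two values lies beyond the scatter. Compound 3 `COc1cc2nccc(Oc3ccc(NC(=O)c4nc(-c5ccc(F)cc5)no4)cc3)c2cc1OC` carries 3-(4-fluorophenyl)-1,2,4-oxadiazol-5-yl in place of 5-(4-fluorophenyl)-1,3-oxazol-2-yl on a carbonyl carbon. Going by the values given here, no measured pair shows this change alone, so no step beyond the scatter is expected in this assay. The estimated step, a 1.4-fold lower number from compound 1 to compound 3 (0.14 log units; within the scatter), is expected to stay within the scatter. Compound 3 is expected at 16000 nM, with an estimated range of 5000 nM to 45000 nM.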

Compound 3, half-maximal inhibitory concentration: > 100000 nM
Compound 3: a limit, no number; the forecaster's own chance of this, stated with the estimate: 15%; middle value at least 6.2-fold (0.79 log units) from the limit.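

In this assay, the reading for compound 3 is a limit of the assay and not a number: the limit of > 100000 nM in this assay, at which 1 of the 3 values shown sits. Even so, the position on the carbonyl carbon proves sensitive to this exchange of five-membered aromatic rings, which gives an at least 4.5-fold higher number from compound 1 to compound 3 (0.65 log units; beyond the scatter). The 4-fluorophenyl ring stands in both groups, so keeping it does not by itself keep the activity of compound 1.

On these data alone, the true size of the step remains unknown. Also open, as far as these compounds go, is how a thiazole ring carrying the same 4-fluorophenyl ring would behave at this position.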